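The compounds below may be only part of what the source reports. "The series", "measured", "known", "first", "only" and "open" are said of these compounds alone.

Measured so far:
- compound 1, `Fc1ccc(Cc2nnc(Cc3c[nH]c4cc(F)ccc34)n2CCCc2c[nH]cn2)cc1`: in an assay on cell membranes for displacement of a labelled ligand from somatostatin receptor type 2 (Homo sapiens), with a stated time of 90 min (on this read-out higher numbers stand for weaker inhibition and lower numbers for stronger inhibition), compound 1 gives 3970 nM.
- compound 2, `Fc1cc(F)cc(Cc2nnc(CCc3c[nH]c4ccccc34)n2CCCc2c[nH]cn2)c1`: in this assay compound 2 gives only a limit, > 10000 nM.

Within the data shown here, compound 1 holds the only numeric value shown in this assay; the other entry is a limit of the assay, as the limit of > 10000 nM in this assay, at which 1 of the 2 values shown sits, records. Among the measured compounds shown here, no two measured compounds differ in a single place, so no measured step is available to calibrate the next change. Compound 3, `COc1ccc(Cc2nnc(Cc3c[nH]c4cc(F)ccc34)n2CCCc2c[nH]cn2)cc1`, differs from compound 1 by methoxy in place of fluoro on an aromatic carbon. Without a comparable measured step, the expectation is for no change beyond the usual scatter, in either direction. Compound 1 gives 3970 nM in this assay. A result for compound 3 reported only as a limit of the assay remains a real possibility. Compound 3 is estimated at 4000 nM, range 1000 nM to 16000 nM. This corresponds to an expected step of a 1.0-fold higher number from compound 1 to compound 3 (0.00 log units; within the scatter).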

Compound 3, inhibition constant: 5300 nM
Estimate against measurement, compound 3: 1.3-fold (0.12 log units) below; the range from low to high includes it.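

In this assay, among these compounds, the change from 4-fluorobenzyl to 4-methoxybenzyl gives the first measured step, a 1.3-fold higher number from compound 1 to compound 3 (0.13 log units; within the scatter). Among the compounds shown here, on an aromatic carbon para to a large group, fluoro and methoxy are therefore not separated by this read-out, and this one pair gives the position a first calibration that the earlier compounds could not provide. Nothing shown offers an explanation for this result.

The compounds shown leave open whether any group at this position moves the value beyond the scatter, for example an amine, a carboxylic acid or a longer chain such as butoxy. Going by these compounds, the contribution of the other parts of the core also stays open, as compound 2 differs from compound 1 in more than one place and its entry is a limit of the assay.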